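Series notes: amino for hydroxymethyl on the cyclohexyl

The source may report more compounds than this note shows. Statements on the series, on what has been measured and on what is new or still open speak of the compounds shown alone.

Going by the values given here, compound 2 `Nc1ncnc2c1c(Oc1cc(C(F)(F)F)ccn1)nn2[C@H]1CC[C@@H](CO)CC1` is the only compound with a number in an ADME assay on microsomes from liver (Mus musculus) for metabolic stability, read by LC-MS, using NADPH, with a stated time of 10 min, tested at 10 uM (on this read-out higher numbers stand for a longer-lived compound and lower numbers for a shorter-lived compound), where compound 2 gives 0.108 h. Compound 1 `Nc1ncnc2c1c(Oc1cc(C(F)(F)F)ccn1)nn2C1CC1` gives in this assay only a limit, > 2.41 h. Among the compounds with values here, the one measured step, an at least 22-fold lower number from compound 1 to compound 2 (1.34 log units; beyond the scatter), rests on the limit (the limit of > 2.41 h in this assay, at which 1 of the 2 values shown sits). Compound 3 `Nc1ncnc2c1c(Oc1cc(C(F)(F)F)ccn1)nn2[C@H]1CC[C@@H](N)CC1` differs from compound 2 by amino in place of hydroxymethyl on a saturated ring carbon. Within the data shown here, no measured step covers this change, so no direction is indicated beyond the scatter; the estimate is the expected step of a 1.9-fold higher number from compound 2 to compound 3 (0.27 log units; within the scatter). Compound 3 is therefore expected to give about 0.2 h, within 0.07 h to 0.6 h.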

Compound 3, half-life: 0.917 h
Compound 3: middle estimate off by 4.6-fold (0.66 log units), on the low side, outside the stated range (above it).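

Amino in place of hydroxymethyl on a saturated ring carbon gives an 8.5-fold higher number from compound 2 to compound 3 (0.93 log units; beyond the scatter) in this assay, so this ring carbon of the cyclohexyl responds to the group it carries. Against cyclopropyl, 4-aminocyclohexyl still gives an at least 2.6-fold lower number from compound 1 to compound 3 (0.41 log units; beyond the scatter), which recovers only part of the loss seen with 4-(hydroxymethyl)cyclohexyl. Compound 1 stands only as a limit, so this last step is a bound: the limit of > 2.41 h in this assay, at which 1 of the 3 values shown sits.

Open, going by these compounds, is whether a methylamino group, a carboxylic acid or a longer chain at this ring carbon would follow amino or hydroxymethyl. On these data alone, the true distance between compound 1 and compound 3 also stays open.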